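Capping the hydroxy of compound 1 with a 3-methylbut-2-en-1-yl group

The compounds below may be only part of what the source reports. "The series", "measured", "known", "first", "only" and "open" are said of these compounds alone.

Compound 1 `COc1cc(O)c(C(=O)/C=C/c2ccc(OC)c(OC)c2)c(OC)c1` gives 27600 nM
Compound 2 `COc1cccc(/C=C/C(=O)c2c(O)cc(OC)cc2OC)c1` gives 3100 nM
Compound 3 `COc1cc(O)c(C(=O)/C=C/c2cccc(OC)c2OC)c(OC)c1` gives 3500 nM

All three values come from a functional assay on HCT-116 cells (Homo sapiens) for antiproliferative activity, read by sulforhodamine B assay, with a stated time of 48 h; a lower number here means a stronger inhibitor, a higher number a weaker inhibitor. Compound 1 has the highest number of the three, which makes it the weakest inhibitor here, while compound 2 and compound 3 sit close together.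

The next compound, compound 4 `COc1cc(OC)c(C(=O)/C=C/c2ccc(OC)c(OC)c2)c(OCC=C(C)C)c1`, comes from compound 1 by one change: 3-methylbut-2-en-1-yl in place of hydrogen on an oxygen on an aromatic ring. In words, 3-methylbut-2-en-1-yl stands in place of hydrogen on an oxygen on an aromatic ring, so hydroxy becomes (3-methylbut-2-en-1-yl)oxy.

For the measured compounds named here, no measured step touches this hydroxy. The two available steps, an 8.9-fold lower number from compound 1 to compound 2 (0.95 log units; beyond the scatter) and a 1.1-fold higher number from compound 2 to compound 3 (0.05 log units; within the scatter), each swap a methoxy and hydrogen on an aromatic carbon. They offer only a rough sense of scale: one change on this core can shift the number clearly or leave it within the scatter. Compound 1 at 27600 nM lies at the top of the range, so a small move towards a lower number in this assay is expected, though perhaps none beyond the scatter. The expected step is a 1.8-fold lower number from compound 1 to compound 4 (0.26 log units; within the scatter). For compound 4 the estimated value is 15000 nM, with an expected range of 5000 nM to 45000 nM.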

Compound 4, half-maximal inhibitory concentration: 5700 nM
The estimate for compound 4 lay 2.6-fold (0.42 log units) above the measured number; the measured number falls inside the stated range.
By their numbers in this assay, from the lowest: compounds 2, 3 and 4 (each within the scatter of the next); then compound 1.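

The earlier steps shown here only swapped methoxy and hydrogen on aromatic carbons, so they said nothing about the hydroxy oxygen of compound 1. Turning that hydroxy into (3-methylbut-2-en-1-yl)oxy gives a 4.8-fold lower number from compound 1 to compound 4 (0.69 log units; beyond the scatter) in this assay, which shows that this position also responds to change and that the hydrogen on this oxygen is not needed for activity in the cells, at least on this core. The data shown offer no independent measurement that could explain this shift, so the reason for it remains unknown.

As far as these compounds go, a single step cannot separate the loss of the hydrogen from the gain of the five-carbon chain, so it remains open whether a small methyl cap would do the same, or whether a saturated 3-methylbutyl chain, a longer chain or a cap carrying an amine or a carboxylic acid would shift the number further. From the compounds shown here alone, it is also open whether the same capping would shift the number to a similar extent on the cores of compound 2 and compound 3, where the methoxy groups on the other aromatic ring are arranged differently.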